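Changing the group on the alkyne of compound 1

This account rests on a few compounds, and the source may have more. Where it says the series, first, only, none or still open, it means among the compounds named here.

Measured compounds:
compound 1, `CN1CCC[C@H]1COc1cncc(C#CCCCCF)c1`: 88000 nM
compound 2, `CN1CCC[C@H]1COc1cncc(C#CCO)c1`: 23000 nM
compound 3, `C#Cc1cncc(OC[C@@H]2CCCN2C)c1`: 6800 nM

All three share one core, and they differ only in what sits on the triple-bonded carbon. In an assay on a protein complex for binding affinity to Neuronal acetylcholine receptor; alpha3/beta4 (Rattus norvegicus) (a lower number here means a stronger inhibitor, a higher number a weaker inhibitor), compound 1 gives the highest of the three numbers, so it is the weakest of the three. The nearest is compound 2, with a 3.8-fold lower number from compound 1 to compound 2 (0.58 log units; beyond the scatter); the furthest is compound 3, with a 13-fold lower number from compound 1 to compound 3 (1.11 log units; beyond the scatter). The step of a 3.4-fold lower number from compound 2 to compound 3 (0.53 log units; beyond the scatter) completes the picture: among these three, the smaller the group on the triple-bonded carbon, the lower the number.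

Compound 4, `CN1CCC[C@H]1COc1cncc(C#Cc2ccccc2)c1`, has not been measured. It differs from compound 1 in one place: phenyl in place of 4-fluorobutyl on a triple-bonded carbon. Among the measured compounds shown here, no measured step introduces a ring at this position, so the two steps from compound 1 give only an indirect guide. Both show that the 4-fluorobutyl chain is the least favourable of the groups seen, so a change away from it is expected to lower the number. Because the change here is of a different kind from a 3.8-fold lower number from compound 1 to compound 2 (0.58 log units; beyond the scatter), a modest step is expected rather than a large one, a 2.9-fold lower number from compound 1 to compound 4 (0.47 log units; beyond the scatter). Compound 4 is therefore expected to give about 30000 nM in this assay, most likely between 8000 nM and 110000 nM.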

Compound 4, inhibition constant: 8100 nM
For compound 4 the middle estimate is 3.7-fold (0.57 log units) above the measured one, within the range that was stated.
By their numbers in this assay, from the lowest: compounds 3 and 4 (each within the scatter of the next); then compound 2; then compound 1.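

The rule that a smaller group on the triple-bonded carbon gives a lower number fails at compound 4: phenyl, with 6 heavy atoms, is larger than 4-fluorobutyl, with 5, yet the change gives an 11-fold lower number from compound 1 to compound 4 (1.04 log units; beyond the scatter) in this assay. Replacing hydrogen with this ring gives a 1.2-fold higher number from compound 3 to compound 4 (0.08 log units; within the scatter), so the two groups cannot be told apart here, while replacing hydroxymethyl with phenyl gives a 2.8-fold lower number from compound 2 to compound 4 (0.45 log units; beyond the scatter), showing that the position accepts an aromatic ring and that heavy-atom count alone does not set the number. Nothing available explains why phenyl behaves so differently from 4-fluorobutyl at this position.

The compounds shown do not separate the effect of chain length from that of the fluorine in compound 1, a question that a plain butyl chain would address directly. They also leave open how the number responds to a phenyl ring carrying a methoxy group or to a chain ending in an amine or a carboxylic acid.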